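Chloro for Methyl on a Thiourea Indole Series

The source may report more compounds than this note shows. Statements on the series, on what has been measured and on what is new or still open speak of the compounds shown alone.

Measured so far:
- Compound 1 `Oc1ccccc1NC(=S)Nc1ccc2[nH]ccc2c1`: 4000 nM in an assay on cells for inhibition of Amine oxidase [flavin-containing] B (Homo sapiens), read by spectrophotometry; a lower number here means a stronger inhibitor, a higher number a weaker inhibitor
- Compound 2 `Cc1ccc(NC(=S)Nc2ccc3[nH]ccc3c2)c(O)c1`: 3200 nM in this assay

Among the compounds with values here, compound 2 stands alongside compound 1 in this assay; the only step between them, a 1.3-fold lower number from compound 1 to compound 2 (0.10 log units; within the scatter), is within the scatter, so the two compounds cannot be told apart on these numbers.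

Compound 3 `Oc1cc(Cl)ccc1NC(=S)Nc1ccc2[nH]ccc2c1` carries the change (chloro in place of methyl on an aromatic carbon). Within the data shown here, no measured step shows a chloro entering for a methyl, and the one step on this ring, a 1.3-fold lower number from compound 1 to compound 2 (0.10 log units; within the scatter), was small. There is thus no ground to expect a move beyond the scatter in either direction, and the expected step is no change at the digits printed from compound 2 to compound 3 (within the scatter).

Among the measured compounds shown here, compound 3 is therefore estimated at 3200 nM, with a range from 1400 nM to 7500 nM, the wide range reflecting that no measured step covers this particular exchange.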

Compound 3, half-maximal inhibitory concentration: 300 nM
Compound 3: the middle estimate sits 11-fold (1.03 log units) above what was measured; the whole stated range lies above it.
By their numbers in this assay, from the lowest: compound 3; then compounds 2 and 1 (each within the scatter of the next).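

This place on the ring is not indifferent to what sits there. In this assay, chloro gives an 11-fold lower number from compound 2 to compound 3 (1.03 log units; beyond the scatter) when it replaces methyl and a 13-fold lower number from compound 1 to compound 3 (1.12 log units; beyond the scatter) when it replaces hydrogen, whereas compound 1 and compound 2 cannot be told apart, so a flat result for hydrogen and methyl gave no warning of what chloro would do. Nothing shown offers a measured reason for this gain.

The compounds shown leave open whether the gain is particular to chloro or would also appear with fluoro, bromo, methoxy or trifluoromethyl at this place. They also leave open whether chloro would give a similar gain if the hydroxy group were replaced by an amine or a methoxy group.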